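A few compounds are considered here, and "the series" means these few. Any claim that something is new, unique, unknown or untested is made for them only; others in the source may bear on it.

Of the compounds shown here, two have been measured. Compound 1 `COc1ccc(OC)c(/C=C/c2nnc(Nc3ccc(Cl)cc3)o2)c1` carries a five-membered heteroaromatic linker, and in a functional assay on UACC-257 cells (Homo sapiens) for antiproliferative activity, read by sulforhodamine B assay, with a stated time of 48 h (a higher number here means a weaker inhibitor of growth, a lower number a stronger inhibitor of growth), compound 1 gives 21300 nM. Compound 2 `COc1ccc(OC)c(/C=C/C(=O)N/N=C/c2ccc(Cl)cc2)c1` instead joins the same dimethoxyphenyl vinyl unit through an acyl hydrazone to the 4-chlorophenyl ring, and in this assay compound 2 gives 36500 nM. Of the two numbers, that of compound 2 is the higher, though the gap to compound 1 lies within the scatter, so the two cannot be ranked against each other.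

Compound 3 `COc1ccc(OC)c(/C=C/C(=O)N/N=C/c2ccccc2)c1` has not been measured. It differs from compound 2 in one place: hydrogen in place of chloro on an aromatic carbon, so that the 4-chlorophenyl ring becomes a plain phenyl. For the measured compounds named here, no measured pair in this set shows what such a change does here. In the absence of a measured step, the expectation is a modest loss at most, with a step from compound 2 to compound 3 of a 1.2-fold higher number from compound 2 to compound 3 (0.09 log units; within the scatter) that may well sit within the scatter. Compound 3 is therefore estimated at 45000 nM, with a range from 15000 nM to 130000 nM.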

Compound 3, concentration for 50% growth inhibition: 5760 nM
Beside the measured number, compound 3's estimate is 7.8-fold (0.89 log units) above it; measured number below the stated range.
By their numbers in this assay, from the lowest: compound 3; then compounds 1 and 2 (each within the scatter of the next).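

The chloro group, on an aromatic carbon para to a large group, proves not to be a neutral passenger on this acyl hydrazone: in this assay, replacing it with hydrogen gives a 6.3-fold lower number from compound 2 to compound 3 (0.80 log units; beyond the scatter) and this step lies beyond the scatter. For the compounds shown here, this is the first single-place comparison in the set, and it shows that what this position carries can move growth inhibition, with the plain phenyl ring the stronger inhibitor of this pair and the 4-chlorophenyl ring the weaker. No supporting measurement accompanies this step, so its cause remains unexplained.

Among the compounds shown, this position is defined by chloro and hydrogen alone, so it remains open where a fluoro, methoxy, amino or carboxylic acid group in the same place would fall relative to these two. From the compounds shown here alone, whether the change from 4-chlorophenyl to phenyl would have a similar effect on compound 1, with its five-membered heteroaromatic linker, also remains open.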